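The compounds below may be only part of what the source reports. "The series", "measured", "known", "first", "only" and "open" are said of these compounds alone.

Among the compounds with values here, compound 2, `COC(=O)c1ccc(N(Cc2ccc(C3CCCCC3)cn2)C(=O)[C@H]2CCN2S(=O)(=O)c2c(F)c(F)c(F)c(F)c2F)cc1O`, is one of three compounds measured in a functional assay on MDA-MB-231 cells (Homo sapiens) for antiproliferative activity, with a stated time of 72 h; on this read-out higher numbers stand for an effect only at larger amounts of compound and lower numbers for an effect already at smaller amounts. In this assay compound 2 gives 1800 nM. Compound 1, `COC(=O)c1ccc(N(Cc2ccc(C3CCCCC3)cc2)C(=O)[C@H]2CCN2S(=O)(=O)c2c(F)c(F)c(F)c(F)c2F)cc1O`, gives 2700 nM in this assay, and the change a 1.5-fold lower number from compound 1 to compound 2 (0.18 log units; within the scatter) falls within the scatter, so the two numbers cannot be told apart. Within the data shown here, compound 3, `O=C(NO)c1cc(F)c(N(Cc2ccc(C3CCOCC3)cc2)C(=O)[C@H]2CCN2S(=O)(=O)c2c(F)c(F)c(F)c(F)c2F)cc1O`, gives 5100 nM in this assay; its number stands beyond the scatter from that of compound 2, but the two structures differ in several places, so no single step is drawn between them.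

Compound 4, `O=C1NC(=O)c2cc(N(Cc3ccc(C4CCCCC4)cn3)C(=O)[C@H]3CCN3S(=O)(=O)c3c(F)c(F)c(F)c(F)c3F)ccc21`, has not yet been measured. It differs from compound 2 by a group of 11 heavy atoms (8 carbon, 1 nitrogen, 2 oxygen; one five-membered non-aromatic ring with 1 hetero atom, one six-membered aromatic ring of carbon only) in place of a group of 11 heavy atoms (8 carbon, 3 oxygen; one six-membered aromatic ring of carbon only), on an amide-type nitrogen. Among the measured compounds shown here, none of the measured steps touches this part of the structure: the only single step, that from compound 1 to compound 2, concerns the group on the saturated chain carbon, not the group on the amide-type nitrogen. The expected step of a 1.1-fold higher number from compound 2 to compound 4 (0.05 log units; within the scatter) is therefore set near no change beyond the scatter, with a wide range. Compound 4 is estimated to give 2000 nM in this assay, expected between 600 nM and 7000 nM.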

Compound 4, half-maximal effective concentration: 1700 nM
For compound 4 the middle estimate is 1.2-fold (0.07 log units) above the measured one; the range from low to high includes it.
By their numbers in this assay, from the lowest: compounds 4, 2, 1 and 3 (each within the scatter of the next, the first and the last beyond it).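

In this assay, putting the group with a five-membered non-aromatic ring and a six-membered aromatic ring in place of 3-hydroxy-4-(methoxycarbonyl)phenyl, on the amide-type nitrogen, gives a 1.1-fold lower number from compound 2 to compound 4 (0.02 log units; within the scatter). This is the first single change shown at this position, since the earlier step concerned only the group on the saturated chain carbon. It shows that, on this one pair, the number does not depend on keeping the hydroxy and methoxycarbonyl groups of the group that leaves, and no measurement given here explains this result.

The compounds shown leave open whether a carboxylic acid or an amine on the aromatic ring at this position would also leave the number within the scatter. They also leave open whether the same exchange would give a similar step with 4-cyclohexylphenyl on the saturated chain carbon.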